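Ester to carbamate on the side-chain carbonyl

This account rests on a few compounds, and the source may have more. Where it says the series, first, only, none or still open, it means among the compounds named here.

Of the compounds shown here, two have numbers so far. Compound 1 `C/C1=C\CC[C@@]2(C)O[C@@H]2C(=O)[C@@H]2CC[C@@H](C)[C@](C)(CC1)[C@H]2COC(=O)Oc1ccccc1` carries a phenyl carbonate on the side chain and a ketone on the core; in an assay (Oryctolagus cuniculus) for inhibition of platelet-activating factor receptor (Cavia porcellus) (on this read-out higher numbers stand for weaker inhibition and lower numbers for stronger inhibition), compound 1 gives 550 nM. Compound 2 `CCC(=O)OC[C@H]1[C@H]2CC[C@@H](C)[C@]1(C)CC/C(C)=C/CC[C@@]1(C)O[C@@H]1[C@@H]2O` carries a propanoate ester and a secondary hydroxyl in place of the ketone; in this assay compound 2 gives 340 nM. Within the data shown here, the gap between the two numbers is within the scatter of repeated measurements, so compound 2 and compound 1 cannot be separated on these data, and no step between them is computed here.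

Compound 3 `C/C1=C\CC[C@@]2(C)O[C@@H]2[C@H](O)[C@@H]2CC[C@@H](C)[C@](C)(CC1)[C@H]2COC(=O)N(C)C` keeps the hydroxyl and the side chain of compound 2 and differs only at the carbonyl: dimethylamino in place of ethyl on a carbonyl carbon. Among the measured compounds shown here, no measured pair shows this change, so its effect is not known from the series. With compound 1 and compound 2 both lying in the same region of this assay, a change within the scatter is expected, in no particular direction. The step of a 1.0-fold higher number from compound 2 to compound 3 (0.01 log units; within the scatter) is estimated to stay within the scatter. For compound 3 the expected value in this assay is 350 nM, with a range from 120 nM to 1000 nM.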

Compound 3, half-maximal inhibitory concentration: 180 nM
Beside the measured number, compound 3's estimate is 1.9-fold (0.29 log units) above it, within the range that was stated.
By their numbers in this assay, from the lowest: compounds 3, 2 and 1 (each within the scatter of the next, the first and the last beyond it).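

Among these compounds, this is the first measured pair at this place: with the hydroxyl and the rest of the shared core held constant, dimethylamino in place of ethyl on a carbonyl carbon gives a 1.9-fold lower number from compound 2 to compound 3 (0.28 log units; within the scatter) in this assay. The propanoate ester and the dimethylcarbamate therefore cannot be separated on these data, and the exchange of propanoyloxy for (dimethylcarbamoyl)oxy is tolerated without a change that can be read beyond the scatter. No measurement shown here accounts for the size of this step or gives a reason for it.

The compounds shown leave open how far this tolerance extends, since a single pair gives no trend: a smaller methylamino, a larger diethylamino or a longer chain on the same carbonyl carbon could each read differently in this assay. On these data alone, it also remains open whether dimethylamino on this carbonyl carbon gives a similar reading when the hydroxyl of compound 3 is replaced by a ketone.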